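Larger alkyl at the indole benzo position of compound 1

The source may hold more compounds than are shown below. What is called first, only, known or untested is meant among the compounds shown, and "the series" means these compounds.

Three analogues share one core. Compound 1 `Cc1ccc2c(C3CCN(CCN4CCN(C(C)C)C4=O)CC3)cn(-c3ccc(F)cc3)c2c1` gives 85 nM in an assay on cell membranes for displacement of a labelled ligand from Adrenergic receptor alpha-1 (Rattus norvegicus) (on this read-out lower numbers stand for stronger inhibition and higher numbers for weaker inhibition), the highest of the three numbers. Among the measured compounds shown here, compound 2 `O=C1NCCN1CCN1CCC(c2cn(-c3ccc(F)cc3)c3cc(C(F)(F)F)ccc23)CC1` gives 33 nM, and compound 3 `O=C1NCCN1CCN1CCC(c2cn(-c3ccc(F)cc3)c3cc(F)ccc23)CC1` gives 2.2 nM; the only step between neighbours that differ in one place is a 15-fold lower number from compound 2 to compound 3 (1.18 log units; beyond the scatter), a large move toward stronger binding when a smaller group replaces a bulkier one on the aromatic carbon. Compound 4 `CC(C)c1ccc2c(C3CCN(CCN4CCN(C(C)C)C4=O)CC3)cn(-c3ccc(F)cc3)c2c1` differs from compound 1 by isopropyl in place of methyl on an aromatic carbon. For the measured compounds named here, that step is not the same as the measured one, and the numbers for compounds 1 and 2 show that the tail also differs, so direct support is thin; the one measured step points toward a bulkier group giving a higher number. Compound 4 is therefore expected at about 150 nM, between 50 nM and 450 nM, a step of a 1.8-fold higher number from compound 1 to compound 4 (0.25 log units; within the scatter).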

Compound 4, half-maximal inhibitory concentration: 730 nM
Beside the measured number, compound 4's estimate is 4.9-fold (0.69 log units) below it, outside the stated range (above it).
By their numbers in this assay, from the lowest: compound 3; then compound 2; then compound 1; then compound 4.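

In this assay, among the compounds shown here, isopropyl in place of methyl on this aromatic carbon gives an 8.6-fold higher number from compound 1 to compound 4 (0.93 log units; beyond the scatter), the first reading of a larger alkyl group here with the rest of the molecule unchanged. The direction matches a 15-fold lower number from compound 2 to compound 3 (1.18 log units; beyond the scatter), where the smaller group also gives the lower number, although that pair carries a different tail. Nothing available explains the change in binding.

The compounds shown leave open whether ethyl would fall closer to methyl or to isopropyl. They also leave open how a methoxy group would behave on this carbon.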